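The source may hold more compounds than are shown below. What is called first, only, known or untested is meant among the compounds shown, and "the series" means these compounds.

Series notes. The shared core carries a variable amide substituent on the carbonyl carbon. Compound 1 `COc1cccc2c1c(NS(=O)(=O)c1ccc(Cl)s1)nn2Cc1cccc(CNC(=O)C2COC2)c1` gives 20 nM in a functional assay on CHO cells for antagonist activity at C-C chemokine receptor type 4 (Homo sapiens), read by GTPgammaS binding; on this read-out higher numbers stand for weaker inhibition and lower numbers for stronger inhibition. Compound 2 `COc1cccc2c1c(NS(=O)(=O)c1ccc(Cl)s1)nn2Cc1cccc(CNC(=O)C2CCO2)c1` gives 31.6 nM in this assay, and compound 3 `COc1cccc2c1c(NS(=O)(=O)c1ccc(Cl)s1)nn2Cc1cccc(CNC(=O)C2CCOCC2)c1` gives 31.6 nM. Compound 3 stands level with compound 2 at the digits shown, the two together the highest of the three numbers; the steps of a 1.6-fold higher number from compound 1 to compound 3 (0.20 log units; within the scatter) and no change at the digits printed from compound 2 to compound 3 (within the scatter) are both within the scatter, so the three ring variants on the carbonyl carbon are not separated by this assay. Compound 4 `CN[C@H](C)C(=O)NCc1cccc(Cn2nc(NS(=O)(=O)c3ccc(Cl)s3)c3c(OC)cccc32)c1` carries 1-(methylamino)ethyl in place of oxan-4-yl on a carbonyl carbon. For the measured compounds named here, no measured step covers this change: the steps seen exchange one ring for another, whereas here a ring leaves and an open chain with 1 hydrogen-bond donor and 1 defined stereocentre enters. Since a 1.6-fold higher number from compound 1 to compound 2 (0.20 log units; within the scatter) and a 1.6-fold higher number from compound 1 to compound 3 (0.20 log units; within the scatter) were both within the scatter, the expected step in this assay is a 1.3-fold higher number from compound 3 to compound 4 (0.10 log units; within the scatter), with no firm direction and a wide margin. Compound 4 is estimated at 40 nM, range 10 nM to 160 nM.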

Compound 4, half-maximal inhibitory concentration: 15.9 nM
Compound 4: the middle estimate sits 2.5-fold (0.40 log units) above what was measured; low and high end bracket the measured number.
By their numbers in this assay, from the lowest: compounds 4, 1, 2 and 3 (each within the scatter of the next).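

On a carbonyl carbon whose other neighbour is an amide-type nitrogen, this position is not tied to a ring in this assay: the open chain 1-(methylamino)ethyl gives a 2.0-fold lower number from compound 3 to compound 4 (0.30 log units; within the scatter) and a 2.0-fold lower number from compound 2 to compound 4 (0.30 log units; within the scatter) as well as a 1.3-fold lower number from compound 1 to compound 4 (0.10 log units; within the scatter) against the three ring variants. Exchanging oxan-4-yl, with 0 hydrogen-bond donors, for a chain with 1 hydrogen-bond donor and 1 defined stereocentre therefore does not separate compound 4 from the ring compounds on this read-out. No available evidence bears on the reason for this result.

The compounds shown hold only one open chain at this position, so the contribution of its amine and its stereocentre cannot be taken apart. As far as these compounds go, whether a primary amine, the opposite stereoisomer, a carboxylic acid or a longer chain would read differently stays open.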